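Epimer at the ring carbon: compound 1 to compound 3

The source may hold more compounds than are shown below. What is called first, only, known or untested is meant among the compounds shown, and "the series" means these compounds.

Compound 1 `CO[C@@H]1C(=O)C[C@H]2O[C@]1(C)n1c3ccccc3c3c4c(c5c6ccccc6n2c5c31)C(=O)NC4` and compound 2 `CC(=O)N[C@H]1C[C@H]2O[C@@](C)([C@@H]1O)n1c3ccccc3c3c4c(c5c6ccccc6n2c5c31)C(=O)NC4` have been measured. In an assay on isolated protein for inhibition of protein kinase C theta type (Homo sapiens), read by HTRF (a lower number here means a stronger inhibitor, a higher number a weaker inhibitor), compound 1 gives only a limit, > 2500 nM. In this assay compound 2 gives 270 nM. Compound 1 sits at the limit of > 2500 nM in this assay, at which 1 of the 2 values shown sits, so its standing is known only as that limit. Compound 3 `CO[C@H]1C(=O)C[C@H]2O[C@]1(C)n1c3ccccc3c3c4c(c5c6ccccc6n2c5c31)C(=O)NC4` differs from compound 1 in one place: the two compounds have the same atoms and bonds and differ only in configuration as drawn: 1 of 3 stereo elements differ; a stereocentre at a saturated ring carbon is drawn S in compound 1 and R in compound 3. Among the compounds with values here, no measured pair shows the effect of such a change in configuration. An expected value for compound 3 in this assay is 1500 nM, within 200 nM to 10000 nM, and the step of an at least 1.6-fold lower number from compound 1 to compound 3 (0.22 log units; that floor lies within the scatter) is expected to be modest, since compound 1 is known only as a limit.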

Compound 3, half-maximal inhibitory concentration: 560 nM
Compound 3: the middle estimate sits 2.7-fold (0.43 log units) above what was measured; the range from low to high includes it.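

In this assay compound 1 gives > 2500 nM, which is a limit and not a number. Changing only the configuration at this saturated ring carbon, from S to R, gives an at least 4.4-fold lower number from compound 1 to compound 3 (0.64 log units; beyond the scatter), the first measured effect of such a change in this series. This step therefore rests on stereochemistry at one carbon alone: the fact that compounds 1 and 3 differ only in the configuration as drawn

From the compounds shown here alone, the full size of the step remains open. It is also unknown whether an amine or a carboxylic acid at this ring carbon would behave the same way in either configuration.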